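Swapping the aryl group on the sulfonamide nitrogen

This account rests on a few compounds, and the source may have more. Where it says the series, first, only, none or still open, it means among the compounds named here.

Of the compounds shown here, three sharing one core have been measured in a functional assay on M21 cells (Homo sapiens) for antiproliferative activity, read by sulforhodamine B assay, with a stated time of 48 h; a lower number here means a stronger inhibitor, a higher number a weaker inhibitor. Compound 1 `COc1ccc(NS(=O)(=O)c2ccc(N3CCNC3=O)cc2)cc1` gives 580 nM, compound 2 `CCc1ccc(NS(=O)(=O)c2ccc(N3CCNC3=O)cc2)cc1` gives 480 nM, and compound 3 `Cc1ccc(C)c(NS(=O)(=O)c2ccc(N3CCNC3=O)cc2)c1` gives 27 nM, the lowest of the three numbers and thus the strongest inhibitor so far. The step of a 1.2-fold lower number from compound 1 to compound 2 (0.08 log units; within the scatter) is small, whereas a 21-fold lower number from compound 1 to compound 3 (1.33 log units; beyond the scatter) and an 18-fold lower number from compound 2 to compound 3 (1.25 log units; beyond the scatter) are both large.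

Compound 4 `Cc1ccc(NS(=O)(=O)c2ccc(N3CCNC3=O)cc2)cc1` has not yet been measured. It differs from compound 3 in one place: 4-methylphenyl in place of 2,5-dimethylphenyl on a sulfonamide nitrogen. The group on the sulfonamide nitrogen in compound 4 resembles those in compounds 1 and 2, a phenyl ring carrying a single substituent in the position named 4, rather than the 2,5-dimethylphenyl of compound 3. The two large steps leading to compound 3 both ran from such a singly substituted phenyl, so the reverse change is expected to lose most of what compound 3 gained. Because a 1.2-fold lower number from compound 1 to compound 2 (0.08 log units; within the scatter) shows that the identity of that single substituent barely mattered, the methyl of compound 4 is expected to behave much like the ethyl of compound 2. Compound 4 is therefore expected to give 400 nM in this assay, within 130 nM to 1200 nM, a step of a 15-fold higher number from compound 3 to compound 4 (1.17 log units; beyond the scatter).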

Compound 4, half-maximal inhibitory concentration: 260 nM
Compound 4: the middle estimate sits 1.5-fold (0.19 log units) above what was measured, within the range that was stated.
By their numbers in this assay, from the lowest: compound 3; then compounds 4, 2 and 1 (each within the scatter of the next, the first and the last beyond it).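

In this assay, for the compounds shown here, the step of a 9.6-fold higher number from compound 3 to compound 4 (0.98 log units; beyond the scatter) shows that the advantage of compound 3 holds against a third singly substituted ring, so it does not depend on the methoxy or ethyl group of the earlier compounds. The change is small on paper, with the 2,5-dimethylphenyl at 8 heavy atoms and the 4-methylphenyl at 7, all of them carbon, yet the step is still beyond the scatter. Among the singly substituted rings the choice of substituent counts for far less, since a 1.8-fold lower number from compound 2 to compound 4 (0.27 log units; within the scatter) lies within the scatter and a 2.2-fold lower number from compound 1 to compound 4 (0.35 log units; beyond the scatter) is only modest, while nothing available here explains why the 2,5-dimethylphenyl stands apart.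

The compounds shown leave open whether the advantage needs both methyl groups of the 2,5-dimethylphenyl or only one of them. They also leave open what the sulfonamide nitrogen would tolerate in a phenyl ring carrying a chlorine, an amine or a carboxylic acid.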